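Swapping a Methoxycyclohexyl Ring for an Oxane

A few compounds are considered here, and "the series" means these few. Any claim that something is new, unique, unknown or untested is made for them only; others in the source may bear on it.

Compound 1 `N#Cc1cnc(NCc2cnccc2C(F)(F)F)cc1NC[C@H]1C[C@@H](O)C1`: 4200 nM
Compound 2 `N#Cc1cnc(NCc2cnccc2C(F)(F)F)cc1NC[C@H]1CC[C@@H](O)CC1`: 500 nM
Compound 3 `CO[C@H]1CC[C@H](CNc2cc(NCc3cnccc3C(F)(F)F)ncc2C#N)CC1`: > 10000 nM

In an assay on isolated protein for inhibition of protein kinase C delta type (Homo sapiens), read by TR-FRET, with a stated time of 2 h (on this read-out lower numbers stand for stronger inhibition and higher numbers for weaker inhibition), compound 1 gives 4200 nM and compound 2 gives 500 nM. For compound 3 the assay reports only a limit, > 10000 nM, so compound 3 stands at the weak end of the three, as shown by the limit of > 10000 nM in this assay, at which 1 of the 3 values shown sits. Compound 4 `N#Cc1cnc(NCc2cnccc2C(F)(F)F)cc1NCC1CCOCC1` carries the change (oxan-4-yl in place of 4-methoxycyclohexyl on a saturated chain carbon bound to a nitrogen on an aromatic ring). The measured steps that bear on this are an at least 20-fold higher number from compound 2 to compound 3 (1.30 log units; beyond the scatter) and an at least 2.3-fold higher number from compound 1 to compound 3 (0.37 log units; beyond the scatter), both of them losses that came with the methoxy-bearing ring; compound 4 again has no hydrogen-bond donor on that ring. Only a small step, if any, is expected, an at least 1.2-fold lower number from compound 3 to compound 4 (0.09 log units; that floor lies within the scatter). Compound 4 is therefore estimated at 8000 nM, within 2000 nM to 30000 nM.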

Compound 4, half-maximal inhibitory concentration: 5000 nM
For compound 4 the middle estimate is 1.6-fold (0.20 log units) above the measured one, within the range that was stated.
By their numbers in this assay, from the lowest: compound 2; then compounds 1 and 4 (each within the scatter of the next). At a limit, above all of these: compound 3.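

The oxan-4-yl ring, with no hydrogen-bond donor, gives a measurable value, yet a 10-fold higher number from compound 2 to compound 4 (1.00 log units; beyond the scatter) shows that it does not match 4-hydroxycyclohexyl. Against 3-hydroxycyclobutyl the step is a 1.2-fold higher number from compound 1 to compound 4 (0.08 log units; within the scatter) and leaves these two rings level in this assay. The comparison with 4-methoxycyclohexyl reads an at least 2.0-fold lower number from compound 3 to compound 4 (0.30 log units; that floor lies within the scatter) and cannot be sized further, since the value of compound 3 is a limit: the limit of > 10000 nM in this assay, at which 1 of the 4 values shown sits.

As far as these compounds go, how an amine or a carboxylic acid on the cyclohexyl ring would compare with 4-hydroxycyclohexyl remains open.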